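The source may report more compounds than this note shows. Statements on the series, on what has been measured and on what is new or still open speak of the compounds shown alone.

Compound 1 `O=C(O)/C(S)=C/c1c[nH]c2cc(Br)ccc12` is the stronger of the two compounds measured in an assay on isolated protein for inhibition of Calpain-1 catalytic subunit (Sus scrofa), read by FRET (a lower number here means a stronger inhibitor, a higher number a weaker inhibitor), so far: in this assay compound 1 gives 7 nM, while compound 2 `O=C(O)/C(S)=C/c1ccc(Br)cc1` gives 1500 nM, a difference well beyond the scatter. For the measured compounds named here, the only other measured compound thus lacks the fused two-ring core of compound 1 and carries its bromo on a single ring, so no step between measured compounds isolates the halogen alone.

Compound 3 `O=C(O)/C(S)=C/c1c[nH]c2cc(F)ccc12` keeps the core of compound 1 and changes just the halogen: fluoro in place of bromo on an aromatic carbon. Going by the values given here, with no measured pair showing this swap, the size of the step cannot be read from the data. A modest loss is the expectation, since compound 1 at 7 nM already sits low. The step from a 2.9-fold higher number from compound 1 to compound 3 (0.46 log units; beyond the scatter) is therefore expected to be small and toward a weaker inhibitor. For compound 3 the estimate in this assay is 20 nM, within a range from 5 nM to 80 nM.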

Compound 3, half-maximal inhibitory concentration: 10 nM
Compound 3: middle estimate off by 2.0-fold (0.30 log units), on the high side; the range from low to high includes it.
By their numbers in this assay, from the lowest: compounds 1 and 3 (each within the scatter of the next); then compound 2.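

Fluoro in place of bromo on this aromatic carbon of the shared core gives a 1.4-fold higher number from compound 1 to compound 3 (0.15 log units; within the scatter) in this assay. For the compounds shown here, this is the first measured pair in which only the halogen changes, and it shows that, for this one pair, the two halogens cannot be told apart by this read-out. Nothing measured here accounts for this outcome.

From the compounds shown here alone, whether a methoxy group, an amine or a plain hydrogen on the same carbon would also give a number within the scatter of compound 1 remains open. Also open, going by these compounds, is whether fluoro in place of bromo in compound 2 would give a similarly small step, as one pair on the core of compound 1 does not settle this for other compounds.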